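A few compounds are considered here, and "the series" means these few. Any claim that something is new, unique, unknown or untested is made for them only; others in the source may bear on it.

Measured in a functional assay on KYSE-450 cells (Homo sapiens) for inhibition, read by MTT assay, with a stated time of 48 h; on this read-out higher numbers stand for weaker inhibition and lower numbers for stronger inhibition:
- compound 1 `C/C=C/C(=O)N(Cc1ccc(OC)c(OC)c1)c1cc(OC)c(OC)c(OC)c1`: 39100 nM
- compound 2 `COc1ccc(CNc2cc(OC)c(OC)c(OC)c2)cc1Br`: 39800 nM
- compound 3 `C/C=C/C(=O)N(Cc1ccc(OC)c(N)c1)c1cc(OC)c(OC)c(OC)c1`: 310 nM

Compound 3, at 310 nM, has the lowest number of the three, so it is the strongest inhibitor here. The next compound, compound 4 `C/C=C/C(=O)N(Cc1ccc(OC)c(Br)c1)c1cc(OC)c(OC)c(OC)c1`, keeps everything in compound 3 except one group: bromo in place of amino on an aromatic carbon. In words, this is bromo in place of amino on an aromatic carbon, turning 3-amino-4-methoxyphenyl into 3-bromo-4-methoxyphenyl.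

Among the compounds with values here, one measured step bears on this place: a 130-fold lower number from compound 1 to compound 3 (2.10 log units; beyond the scatter), a large change in which amino replaced methoxy. Within the data shown here, no measured pair shows what bromo does here. Compound 2 carries the same 3-bromo-4-methoxyphenyl group, but it differs elsewhere and gives 39800 nM, so it offers only a loose hint. Losing the amino group took the number up in compound 1, at 39100 nM, so a clearly higher number is expected, though the size is uncertain. The expected change is a 13-fold higher number from compound 3 to compound 4 (1.11 log units; beyond the scatter). For compound 4 the estimated value is 4000 nM, with an expected range from 400 nM to 40000 nM.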

Compound 4, half-maximal inhibitory concentration: 10500 nM
The estimate for compound 4 lay 2.6-fold (0.42 log units) below the measured number; the measured number falls inside the stated range.
By their numbers in this assay, from the lowest: compound 3; then compound 4; then compounds 1 and 2 (each within the scatter of the next).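

Measured in this assay there is a 34-fold higher number from compound 3 to compound 4 (1.53 log units; beyond the scatter) and so bromo cannot stand in for amino on this aromatic carbon, ortho to a methoxy group. Bromo also gains little over methoxy at this spot, with a 3.7-fold lower number from compound 1 to compound 4 (0.57 log units; beyond the scatter) and that modest step is far smaller than the one that amino gives, so among the three groups on this carbon only amino brings the number down sharply. With the 3-bromo-4-methoxyphenyl group held fixed, a 3.8-fold lower number from compound 2 to compound 4 (0.58 log units; beyond the scatter) and this gives a first measure of what the (prop-1-en-1-yl)carbonyl group on the nitrogen adds.

The compounds shown leave open whether a hydroxy group or a methylamino group on this carbon would keep the low number of compound 3. Nothing available here explains the gap between amino and bromo.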